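The source may report more compounds than this note shows. Statements on the series, on what has been measured and on what is new or still open speak of the compounds shown alone.

Of the compounds shown here, three have so far been tested in a functional assay on the whole organism (stomach) for inhibition, with Rattus norvegicus as the target, at a dose of 100 mg/kg by the intraduodenal route (a lower number here means less inhibition, a higher number more inhibition at the dose given (going by the name of the read-out)), and a fourth awaits its measurement. Compound 1 `Cc1ccc(=O)n(CCCCC(=N)S)n1` gives 29.5%. Compound 2 `Cc1ccc(=O)n(CCC(=N)S)n1` gives 73.9%. These two differ in one place only: a group of 3 heavy atoms (1 carbon, 1 nitrogen, 1 sulfur; no ring) in place of a group of 5 heavy atoms (3 carbon, 1 nitrogen, 1 sulfur; no ring), on a saturated chain carbon, two bonds along the chain from an aromatic nitrogen. For the measured compounds named here, the step that this change made, a number 44.4 percentage points higher from compound 1 to compound 2 (beyond the scatter), is the one change that recurs among the compounds here.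

Compound 3 `N=C(S)CCCCCN1N=C(c2ccccc2)CCC1=O` gives 48.5% in this assay, which puts it second highest of the three, below compound 2 and above compound 1. The difference between the core of compound 3 and the core of compound 1 is not broken down here.

Compound 4 `N=C(S)CCCN1N=C(c2ccccc2)CCC1=O` is the compound still to be measured. It stands to compound 3 as compound 2 stands to compound 1: a group of 3 heavy atoms (1 carbon, 1 nitrogen, 1 sulfur; no ring) in place of a group of 5 heavy atoms (3 carbon, 1 nitrogen, 1 sulfur; no ring), on a saturated chain carbon, three bonds along the chain from an amide-type nitrogen in a ring. The place is not word for word the same, since in compound 3 the group sits three bonds along the chain from an amide-type nitrogen in a ring, whereas in compound 1 it sits two bonds along the chain from an aromatic nitrogen, so this is the same kind of change rather than the same change.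

Going by the values given here, for compound 4 the expected step is a number 23.5 percentage points higher from compound 3 to compound 4 (beyond the scatter), smaller than the earlier one, because only the single step of a number 44.4 percentage points higher from compound 1 to compound 2 (beyond the scatter) is known and it was made on a different core. The expectation rests on compound 3 and its value 48.5% as the starting point. Compound 4 is therefore estimated at 72% in this assay. For compound 4 the likely range is estimated to run from 50% to 90%.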

Compound 4, a percentage reported as inhibition, in the whole organism at one dose (the size of the read-out at that dose, not a potency): 50.3%
The estimate for compound 4 lay 21.7 percentage points above the measured number, and the stated range covers the measured number.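

In this assay, the same swap, a group of 3 heavy atoms in place of a group of 5 heavy atoms, gives a number 1.8 percentage points higher from compound 3 to compound 4 (within the scatter), so on this core the swap leaves no difference that can be told apart from the scatter. The change therefore does not carry over from one core to the other at the size first seen, and a step measured on one core is a poor guide to the step on the other: the same change on two cores in this assay, a number 44.4 percentage points higher (beyond the scatter) from compound 1 to compound 2 and a number 1.8 percentage points higher (within the scatter) from compound 3 to compound 4, 42.6 percentage points apart, beyond the scatter of two such steps

For the compounds shown here, with only one pair on each core, this does not show which part of the cores lies behind the gap, how the change would behave on a third core, or how the two pairs would compare at another dose, since each number is a reading at a single dose and not a potency.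

The compounds shown leave open how a longer chain would read on either core, as only two chain lengths appear on each. They also leave open whether an amine or a carboxylic acid at the end of the chain, in place of the sulfur-bearing group, would follow the same course on the two cores.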